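From a Tert-Butyl to an Isopropyl Side Chain

The compounds below may be only part of what the source reports. "The series", "measured", "known", "first", "only" and "open" are said of these compounds alone.

Compound 3 `CC(C)(C)[C@@H](N)C(=O)NCc1ccc(C(F)(F)F)cc1` carries a tert-butyl group beside its amine and a trifluoromethyl on its ring. In a functional assay on the whole organism (strain albino Sprague-Dawley) with Rattus norvegicus as the target, in the maximal electroshock model (a higher number here means that more compound is needed for the effect, a lower number that less compound is needed), compound 3 gives only a limit, < 30 mg/kg, not a number. Compound 3 thus sits at the limit of < 30 mg/kg in this assay, at which 1 of the 3 values shown sits. The change to compound 4 `CC(C)[C@@H](N)C(=O)NCc1ccc(C(F)(F)F)cc1` is hydrogen in place of methyl on a saturated chain carbon bound to three saturated chain carbons. Among the compounds with values here, no measured step is of this kind; the only measured step, a 2.4-fold higher number from compound 1 to compound 2 (0.38 log units; beyond the scatter), changes the ring substituent instead. Compound 1 `CC(C)[C@@H](N)C(=O)NCc1ccc(F)cc1` gives 21 mg/kg in this assay, and compound 2 `Cc1ccc(CNC(=O)[C@H](N)C(C)C)cc1` gives 50 mg/kg. Because compound 1 shows 21 mg/kg and compound 2 shows 50 mg/kg with the same isopropyl side chain, compound 4 is expected to land near them, estimated at 30 mg/kg, ranging from 12 mg/kg to 80 mg/kg. The expected step of a number no lower from compound 3 to compound 4 (the limit leaves the size open) can only be set against a limit.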

Compound 4, dose for half-maximal effect: 13 mg/kg
The estimate for compound 4 lay 2.3-fold (0.36 log units) above the measured number; the range from low to high includes it.
By their numbers in this assay, from the lowest: compounds 4 and 1 (each within the scatter of the next); then compound 2.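

On the ring, trifluoromethyl in place of methyl gives a 3.8-fold lower number from compound 2 to compound 4 (0.59 log units; beyond the scatter) and so separates the two groups, while trifluoromethyl in place of fluoro gives a 1.6-fold lower number from compound 1 to compound 4 (0.21 log units; within the scatter) and does not separate them. With the isopropyl side chain held fixed, methyl on the ring thus stands apart from both fluoro and trifluoromethyl in these three compounds. The change from tert-butyl to isopropyl itself cannot be read: the limit of < 30 mg/kg in this assay, at which 1 of the 4 values shown sits.

Open, going by these compounds, is whether a chloro or methoxy group on the ring would sit with compounds 1 and 4 or with compound 2. Also open, on these data alone, is how an ethyl group or a longer chain in place of isopropyl would compare.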